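The source may report more compounds than this note shows. Statements on the series, on what has been measured and on what is new or still open speak of the compounds shown alone.

In a functional assay on HL-60 cells (Homo sapiens) for inhibition, read by MTT assay, with a stated time of 72 h (a lower number here means a stronger inhibitor, a higher number a weaker inhibitor), compound 1 `Cc1nc(-c2ccccc2)c(C(=O)N2CCN(c3cccc(Cl)c3)CC2)o1` gives 39.2 nM, and compound 2 `Cc1nc(-c2ccc(F)cc2)c(C(=O)N2CCN(c3cccc(Cl)c3)CC2)o1` gives 40.1 nM. Compound 3 `O=C(c1oc(C(F)(F)F)nc1-c1cccc(F)c1)N1CCN(c2cccc(Cl)c2)CC1` stands apart: in this assay compound 3 is recorded as "not active" (no number reported). It therefore offers no single number to start from, and the size of any step away from it cannot be calculated.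

Compound 4 `Cc1nc(-c2cccc(F)c2)c(C(=O)N2CCN(c3cccc(Cl)c3)CC2)o1` differs from compound 3 in one group: methyl in place of trifluoromethyl on an aromatic carbon. In words, this is methyl in place of trifluoromethyl on an aromatic carbon. Compound 4 thus carries the methyl found in compounds 1 and 2, while keeping the 3-fluorophenyl group of compound 3.

Going by the values given here, the only measured step that bears on this is a 1.0-fold higher number from compound 1 to compound 2 (0.01 log units; within the scatter), for fluoro in place of hydrogen on an aromatic carbon, and it lies within the scatter. Among the compounds with values here, that is a single case, and no measured step covers the exchange of trifluoromethyl for methyl itself. Still, compound 2 at 40.1 nM suggests that a fluoro on the aromatic ring need not move the number much. In this assay, compound 4 is therefore expected to give a measurable number close to those of the two methyl compounds, not a repeat of the result for compound 3. For compound 4 the estimated value is 40 nM, with an expected range from 15 nM to 110 nM.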

Compound 4, half-maximal inhibitory concentration: 33.7 nM
The estimate for compound 4 lay 1.2-fold (0.07 log units) above the measured number; the measured number falls inside the stated range.
By their numbers in this assay, from the lowest: compounds 4, 1 and 2 (each within the scatter of the next).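

In this assay, going by these compounds alone, compound 3 is recorded as "not active" (no number reported) while compound 4, which differs only by methyl in place of trifluoromethyl on the aromatic carbon next to the ring nitrogen and next to the ring oxygen, gives 33.7 nM and so has a number where compound 3 has none, although no step between these two can be read as a size. With methyl at this carbon, the 3-fluorophenyl group shared with compound 3 still leaves compound 4 level with the other two methyl compounds, as shown by a 1.2-fold lower number from compound 2 to compound 4 (0.08 log units; within the scatter) and by a 1.2-fold lower number from compound 1 to compound 4 (0.07 log units; within the scatter) for the two comparisons. Among these methyl compounds, then, neither the presence of the fluoro nor the change from 4-fluorophenyl to 3-fluorophenyl separates the numbers.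

Trifluoromethyl appears here only alongside 3-fluorophenyl, so it remains open whether the same group would also leave a phenyl or 4-fluorophenyl compound without a number. On these data alone, how an ethyl group, a longer chain, an amine or a carboxylic acid at this carbon would read also remains open. No measurement at hand speaks to what lies behind the difference between compound 3 and compound 4.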